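Methyl-to-hydrogen step on the fused core, lipophilicity

A few compounds are considered here, and "the series" means these few. Any claim that something is new, unique, unknown or untested is made for them only; others in the source may bear on it.

Compound 1 `CCOC(=O)c1nc2ccccn2c1[N+](=O)[O-]` and compound 2 `CCOC(=O)c1nc2cccc(C)n2c1[N+](=O)[O-]` share one core; compound 3 `Cc1cccc2nc(NC3CCCCC3)c([N+](=O)[O-])n12` and compound 4 `O=[N+]([O-])c1c(NC2CCCCC2)nc2ccccn12` share another. In a physicochemical assay for lipophilicity, measured as octanol-water partition (a lower number here means a more polar compound, a higher number a more lipophilic compound), compound 1 gives 1.05, compound 2 gives 1.2 and compound 3 gives 1.5. The value of compound 3 lies within the scatter of the value of compound 2 but beyond the scatter of the value of compound 1. Between compound 2 and compound 1 the change is hydrogen in place of methyl on an aromatic carbon and the measured step in this assay is a number 0.15 log units lower from compound 2 to compound 1 (within the scatter). The difference between the core of compound 3 and the core of compound 2 is not broken down here. Compound 4 is not yet measured; it differs from compound 3 by hydrogen in place of methyl on an aromatic carbon, which is the same change, at the same kind of place, as that from compound 2 to compound 1. Going by the values given here, for compound 4 the expected step in this assay is a number 0.15 log units lower from compound 3 to compound 4 (within the scatter), resting on the single measured precedent, a number 0.15 log units lower from compound 2 to compound 1 (within the scatter). Compound 4 is therefore estimated at 1.35, with a range from 1.1 to 1.6.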

Compound 4, partition coefficient: 1.5
Beside the measured number, compound 4's estimate is 0.15 log units below it; the measured number falls inside the stated range.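

In this assay, hydrogen in place of methyl on an aromatic carbon gives no change at the digits printed from compound 3 to compound 4 (within the scatter) and, on the other core, a number 0.15 log units lower from compound 2 to compound 1 (within the scatter) so neither pair shows a step beyond the usual scatter. Carried from one core to the other, this change therefore stays within the scatter in both pairs, but two such small steps cannot establish that the methyl is without consequence or that the two cores respond identically. Nothing at hand bears on the reason for either step.

The compounds shown carry only methyl or hydrogen at this place, which leaves open whether a methoxy group or a carboxylic acid there would give steps that agree between the two cores. Also open, on these data alone, is whether the same agreement would hold on a core carrying a longer chain in place of the ethyl ester or the cyclohexylamino group.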